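The source may hold more compounds than are shown below. What is called first, only, known or untested is meant among the compounds shown, and "the series" means these compounds.

Working notes on the series.

Compound 1 `COc1ccc(C(=O)c2cc(C)ccc2OCC(=O)NNC(=O)c2cc3ccccc3oc2=O)cc1` and compound 2 `Cc1ccc(OCC(=O)NNC(=O)c2cc3ccccc3oc2=O)c(C(=O)c2ccccc2)c1` share a core and differ at one place on the phenyl ring of the benzoyl group. Among the measured compounds shown here, in a functional assay on DLA cells (Mus musculus) for cytotoxicity, read by MTT assay, with a stated time of 48 h (on this read-out higher numbers stand for weaker inhibition and lower numbers for stronger inhibition), compound 1 gives 42000 nM and compound 2 gives 86400 nM; the step of a 2.1-fold higher number from compound 1 to compound 2 (0.31 log units; beyond the scatter) therefore leaves compound 2 with the highest of the two numbers measured so far.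

Compound 3 `Cc1ccc(OCC(=O)NNC(=O)c2cc3ccccc3oc2=O)c(C(=O)c2ccc(Cl)cc2)c1` has not been measured. It differs from compound 2 by chloro in place of hydrogen on an aromatic carbon. For the measured compounds named here, no measured step covers a chloro group; the only step bearing on this ring is a 2.1-fold higher number from compound 1 to compound 2 (0.31 log units; beyond the scatter), which shows that a change at this place can move the number modestly, in either sense. A change of similar or smaller size is expected, with direction uncertain, so the step of a 1.2-fold lower number from compound 2 to compound 3 (0.09 log units; within the scatter) is the working expectation. For compound 3 in this assay the estimate is 70000 nM, within 30000 nM to 160000 nM.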

Compound 3, half-maximal inhibitory concentration: 59100 nM
Compound 3: middle estimate off by 1.2-fold (0.07 log units), on the high side; measured number inside the range.
By their numbers in this assay, from the lowest: compounds 1, 3 and 2 (each within the scatter of the next, the first and the last beyond it).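

Among the compounds shown here, the chloro group is the first substituent at this place, para to a large group, that can be set against both hydrogen and methoxy. In this assay, the two steps (a 1.5-fold lower number from compound 2 to compound 3 (0.16 log units; within the scatter) and a 1.4-fold higher number from compound 1 to compound 3 (0.15 log units; within the scatter)) show that compound 3 cannot be separated from either neighbour, although compound 1 and compound 2 are separated beyond the scatter, so these three substituents do not give a clear order. No measurement is available that explains these numbers.

On these data alone, whether an amine, a carboxylic acid or a longer chain on this aromatic carbon would give a step well beyond the scatter remains open. Also open, as far as these compounds go, is whether these steps would hold on a different core, as each change is seen here on the shared core alone.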